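Working notes: the step from compound 3 to compound 4

The source may report more compounds than this note shows. Statements on the series, on what has been measured and on what is new or still open speak of the compounds shown alone.

In an ADME assay on Vero cells (Chlorocebus sabaeus) for cytotoxicity, read by MTT assay, with a stated time of 72 h (on this read-out lower numbers stand for an effect already at smaller amounts and higher numbers for an effect only at larger amounts of compound), compound 1 `O=C(Nc1nc(-c2ccccn2)cs1)c1ccccc1O` gives "not determined" (no result reported), so it supplies no number. Here compound 2 `O=C(Nc1nc(-c2ccccn2)cs1)c1ccccc1Br` gives 3500 nM and compound 3 `O=C(Nc1nc(-c2ccccn2)cs1)c1ccc(Br)cc1` gives 4700 nM, two values within the scatter of each other. Next, compound 4 `O=C(Nc1nc(-c2ccccn2)cs1)c1cccc(Cl)c1` differs from compound 3 by 3-chlorophenyl in place of 4-bromophenyl on a carbonyl carbon, with 3-chlorophenyl in place of 4-bromophenyl on a carbonyl carbon. For the measured compounds named here, the only measured step bearing on this is a 1.3-fold higher number from compound 2 to compound 3 (0.13 log units; within the scatter), also a change on the carbonyl carbon. Going by the values given here, no measured step exchanges bromine for chlorine. The expected result is a 1.2-fold lower number from compound 3 to compound 4 (0.07 log units; within the scatter), so no step beyond the scatter is expected in this assay. For compound 4 the estimate is 4000 nM, with an expected range of 2000 nM to 8000 nM.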

Compound 4, half-maximal effective concentration: 7000 nM
Compound 4: the middle estimate sits 1.8-fold (0.24 log units) below what was measured; measured number inside the range.
By their numbers in this assay, from the lowest: compounds 2, 3 and 4 (each within the scatter of the next).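

In this assay, 3-chlorophenyl on the carbonyl carbon gives a 1.5-fold higher number from compound 3 to compound 4 (0.17 log units; within the scatter) and a 2.0-fold higher number from compound 2 to compound 4 (0.30 log units; within the scatter). A chlorine-bearing ring therefore joins the two bromophenyl compounds with no step beyond the scatter, although the halogen and its ring position both differ in compound 4. No measurement at hand accounts for these values.

A 3-bromophenyl group would be needed to separate the halogen from its ring position. Going by these compounds, it also remains open whether an amine or a carboxylic acid on this ring would give a step beyond the scatter.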